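Methoxy in Place of Iodo: What Compound 3 May Show

The source may report more compounds than this note shows. Statements on the series, on what has been measured and on what is new or still open speak of the compounds shown alone.

Compound 1 `Nc1scc(-c2ccc(F)cc2)c1C(=O)c1ccc(Cl)cc1` and compound 2 `Nc1scc(-c2ccc(I)cc2)c1C(=O)c1ccc(Cl)cc1` share one core and differ at a single aromatic carbon. In a functional assay on CHO cells for agonist activity at adenosine receptor A1 (Homo sapiens), read by fluorescence and ERK phosphorylation, with stated times of 30 min and 1.5 h, tested at 3 uM (a higher number here means a stronger effect of the compound at the concentration tested, a lower number a weaker effect), compound 1 gives 62%, while compound 2 gives 54%. The step between them, a number 8 percentage points lower from compound 1 to compound 2 (within the scatter), does not rise above the scatter of the measurement. Going by the values given here, compound 2 therefore holds the lower of the two numbers so far, yet its nearest neighbour compound 1 sits only within the scatter of it, so no order between the two can be claimed.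

Compound 3 `COc1ccc(-c2csc(N)c2C(=O)c2ccc(Cl)cc2)cc1` has not yet been measured. It departs from compound 2 as follows: methoxy in place of iodo on an aromatic carbon. Among the compounds with values here, the one measured step that bears on this place is a number 8 percentage points lower from compound 1 to compound 2 (within the scatter), the exchange of one group for another on the same aromatic carbon, and it stayed within the scatter. On that basis a further exchange at this carbon is expected to move the read-out little. Compound 3 is accordingly expected to differ from its neighbour by a number 1 percentage points higher from compound 2 to compound 3 (within the scatter), a step not beyond the scatter. Compound 3 is estimated at 55%, with a range from 35% to 75%.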

Compound 3, a percentage reported as activity, at one concentration (the size of the read-out at that concentration, not a potency): 51%
The estimate for compound 3 lay 4 percentage points above the measured number; the measured number falls inside the stated range.
By their numbers in this assay, from the lowest: compounds 3, 2 and 1 (each within the scatter of the next, the first and the last beyond it).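

In this assay the exchange of iodo for methoxy gives a number 3 percentage points lower from compound 2 to compound 3 (within the scatter) and so stays within the scatter, even though the entering group has two heavy atoms in place of one and carries a hydrogen-bond acceptor. Going by these compounds alone, the new information lies in the comparison with the fluoro compound: a number 11 percentage points lower from compound 1 to compound 3 (beyond the scatter) is the first step at this aromatic carbon to pass beyond the scatter, although it is modest, and it separates methoxy from fluoro while iodo remains within the scatter of both. No measurement available here accounts for the difference between the fluoro and methoxy compounds.

The three compounds leave open whether an amine, a carboxylic acid or a longer chain such as butoxy on this carbon would carry the read-out further from that of compound 1 or bring it back. They also leave open whether the modest step seen here would hold at other concentrations, since each number records the size of the effect at one concentration and does not give a potency.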